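Cytotoxicity notes: methoxy replacing the amide chain on compound 1

A few compounds are considered here, and "the series" means these few. Any claim that something is new, unique, unknown or untested is made for them only; others in the source may bear on it.

Measured so far in an ADME assay on Vero cells (Chlorocebus sabaeus) for cytotoxicity; on this read-out higher numbers stand for lower toxicity in this test and lower numbers for higher toxicity in this test:
- compound 1, `O=C(CN1CCCC1)Nc1ccc(-c2nc3cc(C(F)(F)F)ccc3[nH]2)cc1`: > 100000 nM
- compound 2, `Cn1c(-c2ccc(NC(=O)CN3CCN(c4ccccc4)CC3)cc2)nc2cc(C(F)(F)F)ccc21`: 30000 nM
- compound 3, `O=C(CN1CCCC1)Nc1ccc(-c2nc3ccccc3[nH]2)cc1`: > 100000 nM

Compound 1 sits at a limit of this assay, > 100000 nM, not at a number. Compound 3 sits at the same limit, > 100000 nM. Only compound 2 gives a number, 30000 nM. For the measured compounds named here, the one pair that differs in a single place is compound 1 and compound 3; their step is a step that the two limits leave unreadable from compound 1 to compound 3, and its size cannot be read. What the measurements show is the limit of > 100000 nM in this assay, at which 2 of the 3 values shown sit.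

Compound 4, `COc1ccc(-c2nc3cc(C(F)(F)F)ccc3[nH]2)cc1`, is still to be measured in this assay. It differs from compound 1 as follows: methoxy in place of (((pyrrolidin-1-yl)methyl)carbonyl)amino on an aromatic carbon. Going by the values given here, no measured step covers this kind of change, so the expectation rests on where compound 1 and compound 3 stand. The estimate for compound 4 is 70000 nM, with a range from 20000 nM to 200000 nM. The step this estimate implies, an at least 1.4-fold lower number from compound 1 to compound 4 (0.15 log units; that floor lies within the scatter), is expected to lie within the scatter, with a fair chance that compound 4 also returns only a limit.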

Compound 4, half-maximal cytotoxic concentration: 15000 nM
The estimate for compound 4 lay 4.7-fold (0.67 log units) above the measured number; the measured number lies below the stated range.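

In this assay, methoxy in place of (((pyrrolidin-1-yl)methyl)carbonyl)amino on an aromatic carbon gives an at least 6.6-fold lower number from compound 1 to compound 4 (0.82 log units; beyond the scatter), a step that can be read in one direction. Compound 1 gives > 100000 nM, which is a limit and not a number, so the size of this step is only a floor. The read-out therefore responds to the group at this position, which the step between compound 1 and compound 3 could not show, as two limits leave it unreadable.

The compounds shown leave open which part of the departing group goes with the step, and whether an amine, a carboxylic acid or a longer chain at this position would stand with compound 1 or with compound 4. How far the series can be read on either side of the change also remains limited: the limit of > 100000 nM in this assay, at which 2 of the 4 values shown sit.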